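This account rests on a few compounds, and the source may have more. Where it says the series, first, only, none or still open, it means among the compounds named here.

Three compounds have so far been measured in an ADME assay on MDCK cells (Canis lupus familiaris) for cytotoxicity, read by microscopy, with a stated time of 48 h; on this read-out lower numbers stand for higher toxicity in this test and higher numbers for lower toxicity in this test:

Compound 1 `C=Cc1ccsc1CN[C@@H]1C[C@H]2C[C@@H]([C@H]1C)C2(C)C`: compound 1 gives 50000 nM
Compound 2 `CCc1ccsc1CN[C@@H]1C[C@H]2C[C@@H]([C@H]1C)C2(C)C`: compound 2 gives 25000 nM
Compound 3 `C[C@H]1[C@H](NCc2sccc2C2CC2)C[C@H]2C[C@@H]1C2(C)C`: compound 3 gives 25000 nM

Compound 3 stands level with compound 2 at the digits shown, the two together giving the lowest numbers of the three, while compound 1 lies furthest away; the step of a 2.0-fold lower number from compound 1 to compound 3 (0.30 log units; within the scatter) is within the scatter, as are a 2.0-fold lower number from compound 1 to compound 2 (0.30 log units; within the scatter) and no change at the digits printed from compound 2 to compound 3 (within the scatter). Every change tried on this aromatic carbon of the shared core has therefore left the read-out where it was.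

The next compound, compound 4 `C[C@H]1[C@H](NCc2sccc2-c2ccccc2)C[C@H]2C[C@@H]1C2(C)C`, differs from compound 3 by phenyl in place of cyclopropyl on an aromatic carbon. Within the data shown here, no measured step brings in an aromatic ring at this position, so the closest guides are the three steps above, all of them within the scatter. The expectation for compound 4 is therefore a step of a 1.3-fold lower number from compound 3 to compound 4 (0.10 log units; within the scatter) that stays within the scatter, with a somewhat lower number not ruled out since the entering group is the largest yet. The estimated value for compound 4 in this assay is 20000 nM, with a range from 6000 nM to 60000 nM.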

Compound 4, minimum cytotoxic concentration: 12500 nM
Beside the measured number, compound 4's estimate is 1.6-fold (0.20 log units) above it; the measured number falls inside the stated range.
By their numbers in this assay, from the lowest: compounds 4, 2, 3 and 1 (each within the scatter of the next, the first and the last beyond it).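

Phenyl in place of vinyl on this aromatic carbon, two ring bonds from the ring sulfur, gives the first step in this assay that lies beyond the scatter (a 4.0-fold lower number from compound 1 to compound 4 (0.60 log units; beyond the scatter)), although it is modest and all three steps among compounds 1, 2 and 3 stayed within the scatter. That separation holds against compound 1 alone, since phenyl still cannot be told apart from the two other groups (a 2.0-fold lower number from compound 3 to compound 4 (0.30 log units; within the scatter) and a 2.0-fold lower number from compound 2 to compound 4 (0.30 log units; within the scatter)), so the position tolerates a six-membered aromatic ring of carbon with no more than a modest change from vinyl and none that can be read from cyclopropyl or ethyl. Nothing available explains why the read-out differs between the vinyl and phenyl compounds.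

On these data alone, what a pyridyl ring, a primary amine or a carboxylic acid would do on this aromatic carbon stays open, as does whether a methoxy group on the phenyl ring would widen the step. The compounds shown also leave open whether the same phenyl change would give a comparable step on another core.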